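From methyl to 4-methoxybenzyl on an amide-type nitrogen

The source may report more compounds than this note shows. Statements on the series, on what has been measured and on what is new or still open speak of the compounds shown alone.

Of the compounds shown here, two sharing one core have been tested so far in a functional assay on cells (Cancer cell lines, Homo sapiens) for cytotoxicity, with a stated time of 48 h; a higher number here means a weaker inhibitor of growth, a lower number a stronger inhibitor of growth. In it compound 1 `COc1cc(/C=C2/C(=O)N(C)c3ccc(O)cc32)cc(OC)c1OC` gives 5500 nM, and compound 2 `COc1ccc2c(c1)/C(=C\c1cc(OC)c(OC)c(OC)c1)C(=O)N2C` gives 3500 nM. These two values lie within the scatter of each other, so compound 2 cannot be separated from compound 1 on these numbers.

Compound 3 `COc1ccc(CN2C(=O)/C(=C/c3cc(OC)c(OC)c(OC)c3)c3cc(OC)ccc32)cc1` differs from compound 2 by a single change: 4-methoxyphenyl in place of hydrogen on a saturated chain carbon bound to an amide-type nitrogen in a ring. This places 4-methoxyphenyl in place of hydrogen on a saturated chain carbon bound to an amide-type nitrogen in a ring, turning methyl into 4-methoxybenzyl.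

Going by the values given here, the only measured step is a 1.6-fold lower number from compound 1 to compound 2 (0.20 log units; within the scatter). It is small, and it concerns methyl in place of hydrogen on an oxygen on an aromatic ring, so it lies at another place. Among the compounds with values here, no measured pair varies the group on the nitrogen, and the data therefore give no size for this change. No shift beyond the scatter is expected, and the estimated step is a 1.2-fold lower number from compound 2 to compound 3 (0.07 log units; within the scatter). For compound 3 the expected value is 3000 nM, within an estimated range of 600 nM to 12000 nM.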

Compound 3, concentration for 50% growth inhibition: 2400 nM
Compound 3: middle estimate off by 1.3-fold (0.10 log units), on the high side; low and high end bracket the measured number.
By their numbers in this assay, from the lowest: compounds 3, 2 and 1 (each within the scatter of the next, the first and the last beyond it).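

In this assay, turning methyl into 4-methoxybenzyl on the amide-type nitrogen in a ring gives a 1.5-fold lower number from compound 2 to compound 3 (0.16 log units; within the scatter) and so supplies the first measured size for a change at this position. The earlier pair varied only hydrogen and methyl on an oxygen on an aromatic ring, so it said nothing about the group on the nitrogen. Here a whole 4-methoxyphenyl enters at that place, and compound 3 still cannot be separated from compound 2 on these numbers, which shows that this one large addition leaves the read-out within the scatter.

The compounds shown leave open what a plain benzyl without the methoxy, a longer alkyl chain, or a chain ending in an amine or a carboxylic acid would give on this nitrogen. They also leave open whether the same change from methyl to 4-methoxybenzyl would read alike on the core of compound 1, which carries hydrogen on that oxygen. No measurement at hand bears on why this change leaves the number within the scatter.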